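The source may report more compounds than this note shows. Statements on the series, on what has been measured and on what is new or still open speak of the compounds shown alone.

Compound 1 `COc1ccc2c(=O)c(/C=C/C(=O)Nc3ccccc3)coc2c1`: 9050 nM
Compound 2 `COc1ccc(CNC(=O)/C=C/c2coc3cc(OC)ccc3c2=O)cc1`: 7570 nM
Compound 3 `COc1ccc2c(=O)c(/C=C/C(=O)Nc3ccccc3OC)coc2c1`: 32300 nM

In a functional assay on Huh-7 cells (Homo sapiens) for inhibition, read by MTT assay, with a stated time of 48 h (on this read-out higher numbers stand for weaker inhibition and lower numbers for stronger inhibition), compound 3 gives the highest of the three numbers. The nearest is compound 1, and a 3.6-fold higher number from compound 1 to compound 3 (0.55 log units; beyond the scatter); the furthest is compound 2, and a 4.3-fold higher number from compound 2 to compound 3 (0.63 log units; beyond the scatter). Between compound 1 and compound 2, a 1.2-fold lower number from compound 1 to compound 2 (0.08 log units; within the scatter).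

Compound 4 `COc1ccc2c(=O)c(/C=C/C(=O)Nc3ccc(C)cc3)coc2c1` differs from compound 3 in one place: 4-methylphenyl in place of 2-methoxyphenyl on an amide-type nitrogen. Among the measured compounds shown here, of the measured steps, the one from compound 1 to compound 3 bears most on this change, since it shows what the methoxy of compound 3 adds to the number; the step from compound 2 to compound 3 points the same way. For the measured compounds named here, no measured step shows what a methyl on this phenyl does on its own, so its effect is taken as small. Removing the methoxy of compound 3 is therefore expected to lower the number by roughly the size seen in this assay from compound 1 to compound 3, giving a 3.6-fold lower number from compound 3 to compound 4 (0.55 log units; beyond the scatter). Compound 4 is thus estimated at 9000 nM, with a range from 4000 nM to 20000 nM.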

Compound 4, half-maximal inhibitory concentration: > 100000 nM
Compound 4: a limit, no number (the forecaster's own chance of this, stated with the estimate: 5%); middle value at least 11-fold (1.04 log units) away from the limit.
By their numbers in this assay, from the lowest: compounds 2 and 1 (each within the scatter of the next); then compound 3. At a limit, above all of these: compound 4.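

In this assay compound 4 stands at a limit of the assay and not at a number: the limit of > 100000 nM in this assay, at which 1 of the 4 values shown sits. Among the compounds shown here, a single methyl on the phenyl on this amide-type nitrogen therefore gives a large step, an at least 11-fold higher number from compound 1 to compound 4 (1.04 log units; beyond the scatter), and the change from the 4-methoxybenzyl group is also large, an at least 13-fold higher number from compound 2 to compound 4 (1.12 log units; beyond the scatter), whereas the earlier steps were modest or within the scatter. The 4-methylphenyl group also goes past the 2-methoxyphenyl group, with an at least 3.0-fold higher number from compound 3 to compound 4 (0.49 log units; beyond the scatter), so both substituted phenyl groups shown give higher readings than the plain phenyl, and the methyl does so by more.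

As far as these compounds go, how far compound 4 lies beyond its limit stays open. So does whether this holds for other groups on this phenyl, such as a fluorine, a chlorine or an amine, or for a longer chain on this nitrogen.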